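Urea series: ring size on the amide-type nitrogen

The compounds below may be only part of what the source reports. "The series", "measured", "known", "first", "only" and "open" are said of these compounds alone.

Two members of the series have numbers. Compound 1 `Cc1cc(C)c(NC(=O)N(Cc2ccc(-c3ccccc3)o2)C2CCCCCC2)c(C)c1` gives 44 nM in an assay on microsomes from intestine for inhibition of acyl-CoA:cholesterol acyltransferase (Oryctolagus cuniculus); on this read-out lower numbers stand for stronger inhibition and higher numbers for weaker inhibition. Compound 2 `Cc1cc(C)c(NC(=O)N(Cc2cccc(-c3cc[nH]n3)c2)C2CCCCC2)c(C)c1` gives 39 nM in this assay; compound 2 and compound 1 sit within the usual scatter of each other, so the two numbers show no difference that can be read. Among the compounds with values here, no step between measured compounds that differ in one place is available, so nothing about ring size on this nitrogen is known from the measured pairs.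

Compound 3 `Cc1cc(C)c(NC(=O)N(Cc2cccc(-c3cc[nH]n3)c2)C2CCCC2)c(C)c1` has not been measured. It differs from compound 2 as follows: cyclopentyl in place of cyclohexyl on an amide-type nitrogen, in words cyclopentyl in place of cyclohexyl on an amide-type nitrogen. Without a measured precedent, the step is expected to be small: a modest move toward a higher number in this assay, or none beyond the scatter, expressed as a 1.5-fold higher number from compound 2 to compound 3 (0.19 log units; within the scatter). For compound 3 the estimated value in this assay is 60 nM, with a range from 25 nM to 150 nM.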

Compound 3, half-maximal inhibitory concentration: 22 nM
For compound 3 the middle estimate is 2.7-fold (0.44 log units) above the measured one; measured number outside the range, below it.
By their numbers in this assay, from the lowest: compounds 3, 2 and 1 (each within the scatter of the next).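

In this assay, within the data shown here, the first pair that differs in one place, cyclopentyl in place of cyclohexyl on an amide-type nitrogen, gives a 1.8-fold lower number from compound 2 to compound 3 (0.25 log units; within the scatter) and so shows no readable difference between these two rings. On the core shared by compound 2 and compound 3, this nitrogen therefore accepts either the five-membered or the six-membered ring of carbon only without a difference that can be read in this read-out. Nothing available bears on why the two rings read alike.

Still open, as far as these compounds go, is how far this holds on the same nitrogen: for a smaller ring such as cyclobutyl, an open chain such as pentyl, or a cyclohexyl carrying an amine or a carboxylic acid. From the compounds shown here alone, it is also open whether the same swap reads alike on the core of compound 1.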